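Halogenated aryl swap on compound 1: working notes

This account rests on a few compounds, and the source may have more. Where it says the series, first, only, none or still open, it means among the compounds named here.

Going by the values given here, compound 1 `COc1cc(C(=O)N/N=C/c2ccc(F)c(F)c2)cc(OC)c1OC` is the reference point of the two compounds measured so far. In a functional assay on PC-3 cells (Homo sapiens) for antiproliferative activity, read by MTT assay, tested at 5 uM (on this read-out higher numbers stand for a stronger effect at the one concentration tested and lower numbers for a weaker effect), compound 1 gives 43.7%, the highest of the two numbers in hand. Compound 2 `COc1cc(C2=NN(C(C)=O)C(c3ccccc3F)O2)cc(OC)c1OC`, built on a different core, gives 31.6% in this assay, and this gap to compound 1 is beyond the usual scatter.

Among the compounds with values here, no pair of measured compounds differs in a single place, so the series offers no measured guide to the size of the change leading to compound 3 `COc1cc(C(=O)N/N=C/c2cc(Cl)cc(Cl)c2)cc(OC)c1OC`. Compound 3 differs from compound 1 by 3,5-dichlorophenyl in place of 3,4-difluorophenyl on a carbon with a double bond to nitrogen. Both groups are halogenated phenyl rings with no donors or acceptors, and nothing measured here separates one halogen pattern from another.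

Within the data shown here, with no measured step of this kind, the expected step in this assay is small and most likely not beyond the scatter, in either direction. Compound 3 is expected to give about 45% in this assay, within a range from 25% to 65%. The estimated step is a number 1.3 percentage points higher from compound 1 to compound 3 (within the scatter).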

Compound 3, a percentage reported as inhibition, at one concentration (the size of the read-out at that concentration, not a potency): 46.3%
Compound 3: the middle estimate sits 1.3 percentage points below what was measured; the range from low to high includes it.
By their numbers in this assay, from the lowest: compound 2; then compounds 1 and 3 (each within the scatter of the next).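

In this assay, going by these compounds alone, the first measured step at this position is a number 2.6 percentage points higher from compound 1 to compound 3 (within the scatter) and comes with 3,5-dichlorophenyl in place of 3,4-difluorophenyl on a carbon with a double bond to nitrogen. The position therefore accepts this exchange of one halogenated phenyl ring for another with the read-out staying within the scatter, at the one concentration tested, on the core of compound 1. The two rings match in heavy-atom count and in having no hydrogen-bond donors or acceptors, and no measurement in hand bears on why their read-outs lie so close.

Within the data shown here, the step changes the halogen and its pattern together, so the contribution of each cannot be read from it, and a read-out at one concentration gives no potency for either compound. From the compounds shown here alone, how the position responds to anything other than a halogenated phenyl ring remains open, for example a phenyl ring bearing an amine or a carboxylic acid, or a longer alkyl chain in place of the ring.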